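A few compounds are considered here, and "the series" means these few. Any claim that something is new, unique, unknown or untested is made for them only; others in the source may bear on it.

Series notes. Compound 1 `COc1ccc(OC/C(F)=C\CN)cc1` gives 160 nM in an assay on isolated protein for inhibition of Amine oxidase [copper-containing] 3 (Homo sapiens), read by Amplex Red; a lower number here means a stronger inhibitor, a higher number a weaker inhibitor. Compound 2 `NC/C=C(/F)COc1ccc(Oc2ccccc2)cc1` gives 240 nM in this assay, and compound 3 `CC(C)(C)c1ccc(OC/C(F)=C\CN)cc1` gives 210 nM in this assay. Among the three numbers compound 3 stands second highest; its nearest neighbour is compound 2 and its furthest is compound 1, and both gaps lie within the scatter, so no order among the three can be read from these numbers.

The next change takes compound 3 to compound 4 `NC/C=C(/F)COc1ccc(OC(F)(F)F)cc1`: trifluoromethoxy in place of tert-butyl on an aromatic carbon. Within the data shown here, two measured steps bear on this change, since each also alters the group on that aromatic carbon: a 1.3-fold higher number from compound 1 to compound 3 (0.12 log units; within the scatter) and a 1.5-fold higher number from compound 1 to compound 2 (0.18 log units; within the scatter). Neither moved the number beyond the scatter. For compound 4 the expected step is therefore a 1.1-fold lower number from compound 3 to compound 4 (0.02 log units; within the scatter), that is, none beyond the scatter. The estimate for compound 4 in this assay is 200 nM, with a range from 90 nM to 450 nM.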

Compound 4, half-maximal inhibitory concentration: 180 nM
For compound 4 the middle estimate is 1.1-fold (0.05 log units) above the measured one; the range from low to high includes it.
By their numbers in this assay, from the lowest: compounds 1, 4, 3 and 2 (each within the scatter of the next).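

In this assay, among these compounds, a fluorinated group on this aromatic carbon is now seen for the first time, and trifluoromethoxy, with its oxygen and three fluorine atoms, stays within the scatter of the all-carbon tert-butyl (a 1.2-fold lower number from compound 3 to compound 4 (0.07 log units; within the scatter)). Among the compounds shown here, compound 4 is equally unseparated from the other two ethers, with trifluoromethyl in place of phenyl on the oxygen (a 1.3-fold lower number from compound 2 to compound 4 (0.12 log units; within the scatter)) and in place of methyl (a 1.1-fold higher number from compound 1 to compound 4 (0.05 log units; within the scatter)), so no step to compound 4 gives this position an order among its groups. No available evidence accounts for this absence of separation.

Still open, as far as these compounds go, is whether a carboxylic acid, an amine or a hydroxyl on this aromatic carbon would move the number beyond the scatter. Also open, from the compounds shown here alone, is how a change elsewhere in the shared core would compare with these steps.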